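Series notes: aminoquinoline-pyrimidine pairs, moving to compound 4

The source may hold more compounds than are shown below. What is called first, only, known or untested is meant among the compounds shown, and "the series" means these compounds.

Of the compounds shown here, three of this set have been measured in a physicochemical assay for lipophilicity, read by HPLC, in phosphate buffer, measured as octanol-water partition, with a stated time of 24 h, at pH 7.4; a lower number here means a more polar compound, a higher number a more lipophilic compound. Compound 1 `Clc1ccc2c(NCCCNc3nccc(N4CCCC4)n3)ccnc2c1` gives 0.756. Compound 2 `Clc1ccc2c(NCCNc3nccc(Cl)n3)ccnc2c1` gives 0.501. Compound 3 `Clc1ccc2c(NCCCNc3nccc(N4CCCCC4)n3)ccnc2c1` gives 0.845, the highest of the three numbers; its gap to compound 1 lies within the scatter, while its gap to compound 2 lies beyond it.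

The step to compound 4 `Clc1ccc2c(NCCCNc3nccc(N4CCNCC4)n3)ccnc2c1` is piperazin-1-yl in place of piperidin-1-yl on an aromatic carbon. For the measured compounds named here, the one measured step, a number 0.09 log units higher from compound 1 to compound 3 (within the scatter), swaps one saturated ring for another and is small; it does not cover the entry of a second ring nitrogen carrying a hydrogen-bond donor, and compound 2 differs from compound 3 at two places, so only its own value can be compared. Going by the values given here, no measured step therefore directly bears on this change. The counted difference, one hydrogen-bond donor and one hydrogen-bond acceptor more, makes a move to a lower number in this assay the expectation, larger than the scatter. For compound 4 the expected step is a number 1.15 log units lower from compound 3 to compound 4 (beyond the scatter). For compound 4 the estimate is -0.3, within -1.1 to 0.4.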

Compound 4, distribution coefficient: 0.102
Compound 4: the middle estimate sits 0.40 log units below what was measured, within the range that was stated.
By their numbers in this assay, from the lowest: compound 4; then compounds 2, 1 and 3 (each within the scatter of the next, the first and the last beyond it).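

In this assay the aromatic carbon next to the ring nitrogen now shows that the choice of saturated ring can matter here: piperazin-1-yl in place of piperidin-1-yl gives a number 0.74 log units lower from compound 3 to compound 4 (beyond the scatter), a step the earlier swap of saturated rings did not approach. The same entry against pyrrolidin-1-yl gives a number 0.65 log units lower from compound 1 to compound 4 (beyond the scatter), so compound 4 stands apart from both compound 1 and compound 3, which lie within the scatter of each other, and this happens with the heavy-atom count of the group unchanged. Nothing measured here accounts for the size of these steps.

Still open, going by these compounds, is whether the second ring nitrogen or its hydrogen-bond donor hydrogen goes with the shift, a question that morpholin-4-yl or 4-methylpiperazin-1-yl at this place could separate. Also open, on these data alone, is whether the step holds with a shorter chain between the shared core and the six-membered aromatic ring with 2 nitrogen.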